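The compounds below may be only part of what the source reports. "The series", "measured", "known", "first", "only" and "open" are said of these compounds alone.

Compound 1 `CN(C(=O)NC(=O)c1ccccc1F)c1nc(C(F)(F)F)c(C(=O)N/N=C/c2cc(C(F)(F)F)cc(C(F)(F)F)c2)s1` is the stronger of the two compounds measured in a functional assay on HeLa cells (Homo sapiens) for inhibition, read by MTT assay, with a stated time of 72 h; on this read-out higher numbers stand for weaker inhibition and lower numbers for stronger inhibition: compound 1 gives 4.98 ug/mL, while compound 2 `Cc1nc(N(C)C(=O)NC(=O)c2c(F)cccc2F)sc1C(=O)N/N=C/c1cccc(C(F)(F)F)c1` gives 26.8 ug/mL, a gap beyond the usual scatter. Compound 3 `CN(C(=O)NC(=O)c1cccc(C(F)(F)F)c1)c1nc(C(F)(F)F)c(C(=O)N/N=C/c2cc(C(F)(F)F)cc(C(F)(F)F)c2)s1` keeps the shared core of compound 1 and alters a single group: 3-(trifluoromethyl)phenyl in place of 2-fluorophenyl on a carbonyl carbon. Among the compounds with values here, no measured pair shows this exact change, so the size of the step is uncertain; a small shift in either direction, or none beyond the scatter, seems most likely. Compound 3 is expected at 6 ug/mL, within a range from 2.5 ug/mL to 15 ug/mL. The expected step is a 1.2-fold higher number from compound 1 to compound 3 (0.08 log units; within the scatter).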

Compound 3, half-maximal inhibitory concentration: 5.34 ug/mL
Beside the measured number, compound 3's estimate is 1.1-fold (0.05 log units) above it, within the range that was stated.
By their numbers in this assay, from the lowest: compounds 1 and 3 (each within the scatter of the next); then compound 2.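

Placing 3-(trifluoromethyl)phenyl in place of 2-fluorophenyl on this carbonyl carbon gives, in this assay, a 1.1-fold higher number from compound 1 to compound 3 (0.03 log units; within the scatter). Within the data shown here, this is the first pair here that differs in only one place, and it shows that this position tolerates the exchange of one substituted phenyl group for the other without a change beyond the scatter. Nothing measured here offers a reason for this result. From the compounds shown here alone, whether an unsubstituted phenyl group would read the same on this carbonyl carbon remains open. So does the outcome for a phenyl group carrying an amine or a carboxylic acid.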